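The source may report more compounds than this note shows. Statements on the series, on what has been measured and on what is new or still open speak of the compounds shown alone.

Measured so far:
Compound 1 `O=[N+]([O-])c1cc(OCc2ccccc2)ccc1CNc1cc(C(F)(F)F)cc2[nH]ncc12` gives 20% in an assay for inhibition of Indoleamine 2,3-dioxygenase 1 (Homo sapiens), with stated times of 10 min and 60 min, tested at 100 uM; a higher number here means a stronger effect of the compound at the concentration tested, a lower number a weaker effect.
Compound 2 `O=[N+]([O-])c1cccc(CNc2cc(Br)cc3[nH]ncc23)c1` gives 95% in this assay.

Compound 1 stands lowest of the two numbers; compound 2, which differs from compound 1 in more than one place, lies higher by a gap beyond the scatter. Within the data shown here, no pair of measured compounds differs in a single place, so no step of that kind is known. Compound 3 `O=[N+]([O-])c1cc(Cl)ccc1CNc1cc(C(F)(F)F)cc2[nH]ncc12` makes the first such step from compound 1: chloro in place of benzyloxy on an aromatic carbon. The expectation rests only on compound 1 at 20% and on compound 2 at 95%, which carries no benzyloxy group. A moderate rise is expected from compound 1 to compound 3, a number 25 percentage points higher from compound 1 to compound 3 (beyond the scatter), with the understanding that the true step could still fall within the scatter. Compound 3 is therefore estimated at 45% in this assay, with a range from 15% to 80%.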

Compound 3, a percentage reported as inhibition, at one concentration (the size of the read-out at that concentration, not a potency): 77%
The estimate for compound 3 lay 32 percentage points below the measured number; low and high end bracket the measured number.
By their numbers in this assay, from the lowest: compound 1; then compound 3; then compound 2.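

This carbon, para to a large group and meta to a nitro group, is not a silent spot on the core of compound 1: in this assay, chloro in place of benzyloxy gives a number 57 percentage points higher from compound 1 to compound 3 (beyond the scatter). The benzyloxy group and its six-membered aromatic ring are therefore not needed at this carbon for a high read-out, since a single chlorine atom in their place, with the rest of the molecule unchanged, gives the higher number. The step swaps several features at once, so it cannot show which one matters, and no measurement shown explains the change.

From the compounds shown here alone, it remains open whether chlorine itself matters or whether other groups at this carbon, such as methoxy, an amine or a carboxylic acid, would give a similar number. Going by these compounds, whether a chain between benzyloxy and chloro in length would fall between these two numbers also stays unknown.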